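The source may hold more compounds than are shown below. What is called first, only, known or untested is meant among the compounds shown, and "the series" means these compounds.

Of the compounds shown here, three built on one shared core have been tested in a functional assay on A549 cells (Homo sapiens) for cytotoxicity, read by MTT assay, with a stated time of 72 h; a lower number here means a stronger inhibitor, a higher number a weaker inhibitor. Compound 1 `O=C(Nc1ccc(Oc2ccnc3[nH]ccc23)cc1)c1nn(-c2ccc(Br)cc2)ccc1=O` gives 6240 nM, compound 2 `O=C(Nc1ccc(Oc2ccnc3[nH]ccc23)cc1)c1nn(-c2ccccc2)ccc1=O` gives 10500 nM, and compound 3 `O=C(Nc1ccc(Oc2ccnc3[nH]ccc23)cc1)c1nn(-c2ccc(Cl)c(C(F)(F)F)c2)ccc1=O` gives 2190 nM. Compound 2 thus stands at the highest number of the three: the step of a 1.7-fold higher number from compound 1 to compound 2 (0.23 log units; within the scatter) lies within the scatter, while a 4.8-fold lower number from compound 2 to compound 3 (0.68 log units; beyond the scatter) and a 2.8-fold lower number from compound 1 to compound 3 (0.45 log units; beyond the scatter) are modest steps beyond it. All three of these steps alter the aryl group sitting on the aromatic nitrogen.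

Compound 4 `O=C(Nc1ccc(Oc2ccnc3[nH]ccc23)c(F)c1)c1nn(-c2ccccc2)ccc1=O` departs from compound 2 at a different part of the molecule: fluoro in place of hydrogen on an aromatic carbon, the carbon being ortho to a large group and meta to a large group. Going by the values given here, none of the measured steps touches this ring, so none bears directly on the change. What they do show is that the only shift beyond the scatter came from the 4-chloro-3-(trifluoromethyl)phenyl group, which compound 4 does not carry. Adding one fluorine to a carbon ring is a small change, and without a measured comparison the expectation in this assay is a step no larger than the scatter, in either direction. Compound 4 is therefore estimated at 8500 nM, with a range from 4000 nM to 20000 nM. The expected step of a 1.2-fold lower number from compound 2 to compound 4 (0.09 log units; within the scatter) is accordingly small.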

Compound 4, half-maximal inhibitory concentration: 56800 nM
For compound 4 the middle estimate is 6.7-fold (0.82 log units) below the measured one; the measured number lies above the stated range.
By their numbers in this assay, from the lowest: compound 3; then compounds 1 and 2 (each within the scatter of the next); then compound 4.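

In this assay, the step of a 5.4-fold higher number from compound 2 to compound 4 (0.73 log units; beyond the scatter) is the first change shown away from the aryl group on the aromatic nitrogen, and it moves toward a weaker inhibitor. It shows that this aromatic carbon, ortho to a large group and meta to a large group, is sensitive to substitution: replacing a hydrogen with fluoro, just one heavy atom, is enough to carry the number beyond the scatter. Among the earlier compounds, the only steps beyond the scatter involved the much larger 4-chloro-3-(trifluoromethyl)phenyl group and went toward a lower number, whereas this small exchange goes the other way; no measurement shown gives a reason for this step.

As far as these compounds go, whether a chloro, a methyl or a methoxy group on this same carbon would also raise the number remains open, which leaves it unclear whether the effect is specific to fluoro. Also open, from the compounds shown here alone, is whether fluoro here would raise the number by a similar amount in compound 3, which carries 4-chloro-3-(trifluoromethyl)phenyl on the aromatic nitrogen.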